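The compounds below may be only part of what the source reports. "The series", "measured", "known", "first", "only" and "open" are said of these compounds alone.

Working notes on the series. Compound 1 `COc1cccc(CCC(=O)Nc2nc3ccccc3c(=O)s2)c1` carries the shared core with a 3-methoxyphenyl on the chain, and in an assay on CHO cells for displacement of a labelled ligand from adenosine receptor A3 (Homo sapiens), read by scintillation counting, with a stated time of 60 min (a lower number here means a stronger inhibitor, a higher number a weaker inhibitor), compound 1 gives 173 nM. Compound 2 `O=C(CCc1ccccc1Br)Nc1nc2ccccc2c(=O)s1` keeps the core and chain and changes only the aryl group. As far as these compounds go, for compound 2 this assay returns a limit rather than a number, > 1000 nM, so compound 2 stands at the limit of > 1000 nM in this assay, at which 1 of the 2 values shown sits, and its true inhibition constant is unknown beyond that. Within the data shown here, the one measured step in this set is an at least 5.7-fold higher number from compound 1 to compound 2 (0.76 log units; beyond the scatter), and it ends at the limit.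

Compound 3 `O=C(CCc1ccccc1F)Nc1nc2ccccc2c(=O)s1` is the next candidate; the change from compound 2 is fluoro in place of bromo on an aromatic carbon. Among the measured compounds shown here, no measured step exchanges one halogen for another, so there is nothing in the data that speaks directly to this change; the only step on record leads into compound 2 and says nothing about leaving it. With compound 2 at a limit, the expectation for compound 3 is a step that the limit leaves unreadable from compound 2 to compound 3, which is no change beyond the scatter. Compound 3 is therefore expected at about 1500 nM, within a range of 400 nM to 6000 nM, with a real chance that this assay again reports only a limit.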

Compound 3, inhibition constant: >= 1000 nM
Compound 3: no number, only a limit; the forecaster's own chance of this, stated with the estimate: 50%; the middle value lies beyond the limit too.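

Compound 3 gives only a limit, not a number, in this assay: the limit of >= 1000 nM in this assay, at which 1 of the 3 values shown sits.

The step from compound 2 cannot be read, since both ends are limits, so fluoro and bromo on this aromatic carbon are not ranked against each other. Against compound 1 the change to 2-fluorophenyl gives an at least 5.7-fold higher number from compound 1 to compound 3 (0.76 log units; beyond the scatter), so the loss seen with 2-bromophenyl recurs with a second halogen and is not confined to bromo; within the compounds shown, no 2-halophenyl group matches the 3-methoxyphenyl of compound 1.

As far as these compounds go, in both of these changes the substituent and its place on the ring differ together, so it remains open whether the loss follows the halogen or the place, and a 2-methoxyphenyl or a 3-fluorophenyl on the same chain would separate the two. Also open, from the compounds shown here alone, are how far the true inhibition constants of compound 2 and compound 3 lie beyond their limits, and whether an unsubstituted phenyl or a longer chain would hold the level of compound 1.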